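Oxime ethers with arylpiperazines: maximal response at the dopamine receptor

The source may report more compounds than this note shows. Statements on the series, on what has been measured and on what is new or still open speak of the compounds shown alone.

Measured compounds:
compound 1 `CCO/N=C(\CCN1CCN(c2ccccc2)CC1)c1ccccc1` — 80%
compound 2 `CCO/N=C(\CCN1CCN(c2ccccc2OC)CC1)c1ccccc1` — 76%
compound 3 `CCO/N=C(\CCN1CCN(c2cccc(OC)c2)CC1)c1ccccc1` — 30%

In a functional assay on HEK293 cells with D(4) dopamine receptor (Homo sapiens) as the target, read by FLIPR (a higher number here means a larger maximal response, a lower number a smaller maximal response), compound 3 gives 30%, the lowest of the three numbers; compound 2 is the nearest, a number 46 percentage points lower from compound 2 to compound 3 (beyond the scatter), and compound 1 the furthest, a number 50 percentage points lower from compound 1 to compound 3 (beyond the scatter). Compound 1 and compound 2 lie within the scatter of each other, a number 4 percentage points lower from compound 1 to compound 2 (within the scatter).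

Compound 4 `CCO/N=C(\CCN1CCN(c2cccc(OCC)c2)CC1)c1ccccc1` differs from compound 3 by methyl in place of hydrogen on a saturated chain carbon bound to an oxygen on an aromatic ring. Among the compounds with values here, none of the three measured steps alters this chain: they add a methoxy or move it on the ring, so no step bears directly on compound 4. The expectation for this assay is therefore a step of a number 2 percentage points higher from compound 3 to compound 4 (within the scatter), not beyond the scatter. Compound 4 is estimated at 32%, range 15% to 50%.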

Compound 4, largest response reached (reported as efficacy), in percent of the reference or control that the assay uses: 84%
For compound 4 the middle estimate is 52 percentage points below the measured one; the measured number lies above the stated range.
By their numbers in this assay, from the lowest: compound 3; then compounds 2, 1 and 4 (each within the scatter of the next).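

In this assay, the change from methoxy to ethoxy on the 3-substituted phenyl is large (a number 54 percentage points higher from compound 3 to compound 4 (beyond the scatter)), so one methyl on the saturated chain carbon bound to the oxygen decides the outcome here. The other steps (a number 8 percentage points higher from compound 2 to compound 4 (within the scatter); a number 4 percentage points higher from compound 1 to compound 4 (within the scatter)) put compound 4 level with compound 1 and compound 2, so within this series the low number belongs to 3-methoxyphenyl, not to 3-ethoxyphenyl. Nothing available accounts for this step. Open, from the compounds shown here alone, is whether propoxy, a longer chain, or hydroxyl in place of ethoxy keeps the response of compound 4.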